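The source may report more compounds than this note shows. Statements on the series, on what has been measured and on what is new or still open speak of the compounds shown alone.

Compound 1 `COc1ccc(C(=O)/C=C/c2cccc(F)c2)c2c1C=CC(C)(C)O2` gives in a functional assay on HCT-116 cells (Homo sapiens) for antiproliferative activity, read by MTT assay, with a stated time of 24 h (a higher number here means a weaker inhibitor, a lower number a stronger inhibitor), a value of > 10000 nM, which is a limit of the assay.
Compound 2 `COc1ccc(C(=O)/C=C/c2ccc([N+](=O)[O-])cc2)c2c1C=CC(C)(C)O2` gives in this assay a value of 8880 nM.
Compound 3 `COc1ccc(C(=O)/C=C/c2ccsc2)c2c1C=CC(C)(C)O2` gives in this assay a value of > 10000 nM, which is a limit of the assay.

Compound 3 therefore stands at the limit rather than at a number, and the limit of > 10000 nM in this assay, at which 2 of the 3 values shown sit, shows that compound 1 sits there as well. For the measured compounds named here, the step that the two limits leave unreadable from compound 1 to compound 3 cannot be read, and the step of an at least 1.1-fold higher number from compound 2 to compound 3 (0.05 log units; that floor lies within the scatter) has a floor that lies within the scatter, so none of the measured steps gives a usable size. Going by the values given here, compound 4 `COc1ccc(C(=O)/C=C/c2ccc(O)c(Br)c2)c2c1C=CC(C)(C)O2` differs from compound 3 as follows. 3-bromo-4-hydroxyphenyl in place of thiophen-3-yl on a double-bonded chain carbon bound to a double-bonded chain carbon No measured step involves 3-bromo-4-hydroxyphenyl, and the only change among the measured compounds that reached a number, an at least 1.1-fold lower number from compound 1 to compound 2 (0.05 log units; that floor lies within the scatter), is small. The expectation for this assay is thus a step of an at least 1.1-fold lower number from compound 3 to compound 4 (0.04 log units; that floor lies within the scatter), that is, none clearly beyond the scatter, with a fair chance that again only a limit is reported. Compound 4 is estimated at 9000 nM, in a range from 3000 nM to 30000 nM.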

Compound 4, half-maximal inhibitory concentration: > 10000 nM
Compound 4: a limit, no number; the forecaster's own chance of this, stated with the estimate: 50%; middle value at least 1.1-fold (0.04 log units) from the limit.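

At this place, on a double-bonded chain carbon bound to a double-bonded chain carbon, 3-bromo-4-hydroxyphenyl adds a hydrogen-bond donor and a bromine to the groups shown, yet in this assay compound 4 gives > 10000 nM, which is a limit and not a number. A six-membered aromatic ring carrying these two features therefore ends in the same place as the 3-fluorophenyl and thiophen-3-yl groups: the limit of > 10000 nM in this assay, at which 3 of the 4 values shown sit. The steps from compound 1 and from compound 3 cannot be read, and the step of an at least 1.1-fold higher number from compound 2 to compound 4 (0.05 log units; that floor lies within the scatter) gives no usable size for this change.

From the compounds shown here alone, whether an amine or a carboxylic acid on this ring, or a longer chain in its place, would give a number clearly beyond the scatter stays open. Going by these compounds, how far apart the compounds at the limit truly lie also stays open.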